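Changing the carboxyphenyl group of compound 2

The compounds below may be only part of what the source reports. "The series", "measured", "known", "first", "only" and "open" are said of these compounds alone.

In an ADME assay (liver) for metabolic stability, with Liver microsome (Rattus norvegicus) as the target, read by LC-MS, using microsomes and NADPH, with stated times of 5 min and 60 min, tested at 4 uM (on this read-out lower numbers stand for a less stable compound and higher numbers for a more stable compound), compound 1 `CCCC(=O)c1ccc(OCCCCOc2cc(C(=O)O)ccc2OC)c(C)c1O` gives 1%, compound 3 `COc1ccc(C(=O)O)cc1OCCCCOc1ccc(C(=O)CC(C)C)c(O)c1C` gives 5% and compound 2 `COc1ccc(C(=O)O)cc1OCCCCOc1ccc(C(=O)CC2CCCC2)c(O)c1C` gives 14%. The data show a number 13 percentage points higher from compound 1 to compound 2 (beyond the scatter) and a number 9 percentage points lower from compound 2 to compound 3 (within the scatter), so compound 2 stands apart from only one of the other two. Compound 4 `Cc1cc(OCCCCOc2ccc(C(=O)CC3CCCC3)c(O)c2C)ccc1C(=O)O` differs from compound 2 elsewhere: 4-carboxy-3-methylphenyl in place of 5-carboxy-2-methoxyphenyl on an oxygen on a saturated carbon. All three measured steps concern the saturated chain carbon bound to a carbonyl carbon, or a carbon of that chain, and none touches this place. They therefore give no size or direction for the change, and no step beyond the scatter is foreseen. The expected change is no change at the digits printed from compound 2 to compound 4 (within the scatter). Compound 4 is estimated at 14%, with an expected range of 3% to 35%.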

Compound 4, percent of the compound remaining: 55%
Beside the measured number, compound 4's estimate is 41 percentage points below it, and the stated range ends below it.
By their numbers in this assay, from the lowest: compounds 1, 3 and 2 (each within the scatter of the next, the first and the last beyond it); then compound 4.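

In this assay, the group on the oxygen on a saturated carbon proves a far stronger lever than the chain changes: 4-carboxy-3-methylphenyl in place of 5-carboxy-2-methoxyphenyl gives a number 41 percentage points higher from compound 2 to compound 4 (beyond the scatter) as a large step, where those changes gave a modest step at most. Nothing available here accounts for this gain. The new group differs from the old one in both the carboxy placement and methyl for methoxy, and the compounds shown do not separate these two changes. They also leave open whether an amide in place of the carboxylic acid, or chlorine in place of the methyl, would keep the gain.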